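Changing the amide side chain of compound 1

This account rests on a few compounds, and the source may have more. Where it says the series, first, only, none or still open, it means among the compounds named here.

In a functional assay on MCF7 cells (Homo sapiens), read by MTT assay, with a stated time of 48 h (a higher number here means a weaker inhibitor, a lower number a stronger inhibitor), compound 1 `CCn1c(C(=O)NCCN(C)C)ccc1C(CC)(CC)c1ccc(OCC(=O)C(C)(C)C)c(C)c1` gives 520 nM and compound 2 `CCn1c(C(=O)NCCN(C)C)ccc1C(CC)(CC)c1ccc(OCC(O)C(C)(C)C)c(C)c1` gives 660 nM. The step between them is a 1.3-fold higher number from compound 1 to compound 2 (0.10 log units; within the scatter), and it lies away from the carbonyl carbon that matters here. Compound 3 `C#CC(C)OC(=O)c1ccc(C(CC)(CC)c2ccc(OCC(O)C(C)(C)C)c(C)c2)n1CC` gives > 50000 nM, which is a limit of the assay and not a number. Compound 4 `CCn1c(C(=O)N(C)CC(=O)O)ccc1C(CC)(CC)c1ccc(OCC(=O)C(C)(C)C)c(C)c1` carries (carboxymethyl)(methyl)amino in place of (2-(dimethylamino)ethyl)amino on a carbonyl carbon. The same group left in one measured step, an at least 75-fold higher number from compound 2 to compound 3 (1.87 log units; beyond the scatter), so a large move towards weaker inhibition is expected in this assay, although the entering group differs. The estimated change is a 29-fold higher number from compound 1 to compound 4 (1.46 log units; beyond the scatter). For compound 4 the expected value is 15000 nM, with an estimated range of 2500 nM to 50000 nM.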

Compound 4, half-maximal inhibitory concentration: 28600 nM
The estimate for compound 4 lay 1.9-fold (0.28 log units) below the measured number; measured number inside the range.
By their numbers in this assay, from the lowest: compounds 1 and 2 (each within the scatter of the next); then compound 4. At a limit, above all of these: compound 3.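

In this assay, putting (carboxymethyl)(methyl)amino in place of (2-(dimethylamino)ethyl)amino on the carbonyl carbon gives a 55-fold higher number from compound 1 to compound 4 (1.74 log units; beyond the scatter). This gives the loss at this carbonyl carbon a measured size, and it shows that the loss also occurs when a nitrogen stays bound to that carbon. Compound 3 alone stands at a limit, which is not a number: the limit of > 50000 nM in this assay, at which 1 of the 4 values shown sits.

The compounds shown cannot separate the effect of losing the dimethylamino group from that of gaining the carboxylic acid. On these data alone, a longer chain such as (3-(dimethylamino)propyl)amino or a small methylamino group on the same carbon remains open.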